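Phenyl in place of ethyl on the core of compound 1

The source may hold more compounds than are shown below. What is called first, only, known or untested is meant among the compounds shown, and "the series" means these compounds.

Among the measured compounds shown here, compound 1 `CC[C@@H]1O[C@H](COCc2ccccc2)[C@@H](OCc2ccccc2)[C@H](OCc2ccccc2)[C@H]1O` is the only member of this set with a numbered result: in a functional assay on HOS cells (Homo sapiens) for antiproliferative activity, read by sulforhodamine B assay (a lower number here means a stronger inhibitor of growth, a higher number a weaker inhibitor of growth), compound 1 gives 34200 nM. Compound 2 `CC[C@H]1O[C@H](COCc2ccccc2)[C@@H](OCc2ccccc2)[C@H](OCc2ccccc2)[C@H]1O` reaches only a limit of the assay, > 50000 nM. Compound 3 `CC(=O)O[C@@H]1[C@@H](OCc2ccccc2)[C@H](OCc2ccccc2)[C@@H](COCc2ccccc2)O[C@@H]1CC(C)C` likewise stands at a limit, > 50000 nM. For the measured compounds named here, that two of the three values sit at the limit of > 50000 nM in this assay, at which 2 of the 3 values shown sit, sets compound 1 as the one anchor with a number. Going by the values given here, the single measured step, an at least 1.4-fold higher number from compound 1 to compound 2 (0.16 log units; that floor lies within the scatter), rests on the fact that the two compounds differ only in configuration as drawn (the fact that compounds 1 and 2 differ only in the configuration as drawn); its floor lies within the scatter and carries no direction.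

Compound 4 `O[C@@H]1[C@@H](OCc2ccccc2)[C@H](OCc2ccccc2)[C@@H](COCc2ccccc2)O[C@H]1c1ccccc1` differs from compound 1 by phenyl in place of ethyl on a saturated ring carbon. Among the compounds with values here, no measured step touches a change of this kind: the step from compound 1 to compound 2 exchanges no group, and compound 3 has no partner differing in one place. The expectation for compound 4 therefore rests on compound 1 alone. No move beyond the scatter is expected in this assay, and compound 4 is estimated at 30000 nM, within 8000 nM to 100000 nM. The expected step is a 1.1-fold lower number from compound 1 to compound 4 (0.06 log units; within the scatter).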

Compound 4, concentration for 50% growth inhibition: > 50000 nM
Compound 4 ended at the assay's limit (the forecaster's own chance of this, stated with the estimate: 35%); at least 1.6-fold (0.22 log units) between middle value and limit.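

Among the compounds shown here, this is the first exchange of a group that can be read on the saturated ring carbon next to the ring oxygen: in this assay, phenyl in place of ethyl gives an at least 1.4-fold higher number from compound 1 to compound 4 (0.16 log units; that floor lies within the scatter). Compound 4 stands at a limit of this assay, > 50000 nM, and this is not a number. Phenyl therefore brings no measurable growth inhibition to this position on the shared core, but the step cannot show how far compound 4 lies from compound 1, and compound 1 remains the only compound in the series with a number: the limit of > 50000 nM in this assay, at which 3 of the 4 values shown sit.

For the compounds shown here, how the configuration at this ring carbon reads with phenyl in place of ethyl remains open, since the only pair differing in configuration carries ethyl and its step has a floor within the scatter. Also open, from the compounds shown here alone, is whether an aminomethyl group or a carboxylic acid on this ring carbon would give a number under the limit, and so whether this position can yield any stronger inhibitor of growth than compound 1.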